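The source may hold more compounds than are shown below. What is called first, only, known or untested is meant among the compounds shown, and "the series" means these compounds.

Compound 1 `COc1ccc(/C=C/S(=O)(=O)Nc2c(F)c(F)c(F)c(F)c2F)cc1N`: 35000 nM
Compound 2 `O=S(=O)(/C=C/c1ccc(Br)cc1)Nc1ccc(F)cc1`: 10000 nM

In a functional assay on K562 cells (Homo sapiens) for cytotoxicity, read by trypan blue exclusion, with a stated time of 96 h (on this read-out higher numbers stand for weaker inhibition and lower numbers for stronger inhibition), compound 2 gives 10000 nM, the lower of the two numbers, and so the stronger inhibition. Compound 1 gives 35000 nM, and the gap between the two lies beyond the scatter. These two compounds differ in more than one place, so no single structural change can be read from the gap.

Compound 3 `COc1ccc(/C=C/S(=O)(=O)Nc2ccc(F)cc2)cc1` has not yet been measured in this assay. It carries methoxy in place of bromo on an aromatic carbon, para to a large group: methoxy in place of bromo on an aromatic carbon. Among the compounds with values here, no measured pair isolates this change. Compound 1, at 35000 nM, also bears a methoxy, but it offers no clean guide, as its other differences from compound 2 cannot be separated out. With so little to go on, the expectation stays close to the value of compound 2, with no firm direction. The expected step is a 1.3-fold lower number from compound 2 to compound 3 (0.10 log units; within the scatter), not beyond the scatter. Compound 3 is estimated at 8000 nM, with an expected range of 2500 nM to 25000 nM.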

Compound 3, half-maximal inhibitory concentration: 10000 nM
Compound 3: middle estimate off by 1.3-fold (0.10 log units), on the low side; the range from low to high includes it.
By their numbers in this assay, from the lowest: compounds 2 and 3 (each within the scatter of the next); then compound 1.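

In this assay the series now has its first pair that differs in one place, and it reads no change at the digits printed from compound 2 to compound 3 (within the scatter) for methoxy in place of bromo on an aromatic carbon, para to a large group. At this position, then, bromo with 0 hydrogen-bond acceptors and methoxy with 1 hydrogen-bond acceptor give values within the scatter of each other, so the exchange of these two groups, with 1 heavy atom leaving and 2 entering, brings no step beyond the scatter on this read-out. Nothing on hand bears on why the two groups read alike.

This single pair leaves open whether other groups at the same position, such as an amine, a carboxylic acid or a nitrile, would also stay within the scatter of compound 2 and compound 3. Compound 1, at 35000 nM, still differs from both of them in more than one place, so the separate contributions of its amine and of the fluorines on its other ring remain unresolved.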